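Ortho substituent on the benzoyl hydrazone and cytotoxicity

This account rests on a few compounds, and the source may have more. Where it says the series, first, only, none or still open, it means among the compounds named here.

Compound 3 `CC(/C=N/Nc1ccc([N+](=O)[O-])cc1)=N\NC(=O)c1ccccc1C` in an ADME assay on J774 cells (Mus musculus, strain BALB/c) for cytotoxicity, read by resazurin assay, with a stated time of 72 h (a higher number here means that more compound is tolerated, a lower number that less compound is tolerated), gives only a limit, > 100000 nM. Compound 1 `CC(/C=N/Nc1ccc([N+](=O)[O-])cc1)=N\NC(=O)c1ccccc1Nc1ccccc1` likewise reaches only a limit there, > 100000 nM. Compound 2 `CC(/C=N/Nc1ccc([N+](=O)[O-])cc1)=N\NC(=O)c1ccccc1O` gives 29500 nM. Compound 3 therefore stands at the top of the numbers shown, together with compound 1, and both of these values are limits (the limit of > 100000 nM in this assay, at which 2 of the 3 values shown sit). Compound 4 `CC(/C=N/Nc1ccc([N+](=O)[O-])cc1)=N\NC(=O)c1ccccc1Oc1ccccc1` differs from compound 3 by phenoxy in place of methyl on an aromatic carbon. Of the measured steps, an at least 3.3-fold higher number from compound 2 to compound 3 (0.53 log units; beyond the scatter) bears on this change, while a step that the two limits leave unreadable from compound 1 to compound 3. Compound 1, which carries a large aromatic group, also sits at the limit. For compound 4 a step that the limit leaves unreadable from compound 3 to compound 4 is expected, not beyond the scatter. Compound 4 is estimated at 150000 nM, within 50000 nM to 500000 nM.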

Compound 4, half-maximal cytotoxic concentration: > 100000 nM
Compound 4: no number, only a limit; the forecaster's own chance of this, stated with the estimate: 70%; the middle value is on the limit's open side.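

Phenoxy on this aromatic carbon, ortho to a large group, joins anilino and methyl at the limit: compound 4 gives only a limit in this assay, > 100000 nM. Phenyl in place of hydrogen on the oxygen gives an at least 3.3-fold higher number from compound 2 to compound 4 (0.53 log units; beyond the scatter), so hydroxy remains the only group shown with a readable number. The steps among the three compounds at the limit cannot be read: the limit of > 100000 nM in this assay, at which 3 of the 4 values shown sit.

On these data alone, whether those three groups differ from one another stays open. Also open, as far as these compounds go, is whether an amine or a carboxylic acid here would give a readable number.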